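From propoxymethyl to isopropoxymethyl on a shared core

The compounds below may be only part of what the source reports. "The series", "measured", "known", "first", "only" and "open" are said of these compounds alone.

Compounds measured in a functional assay on MES-SA/Dx5 cells (Homo sapiens) for inhibition, with a stated time of 72 h (a higher number here means a weaker inhibitor, a lower number a stronger inhibitor), and their values
- compound 1 `Oc1c(CN2CCCCC2)ccc2cccnc12` with 850 nM; 832 nM (2 entries)
- compound 2 `CCOCc1cc(CN2CCCCC2)c(O)c2ncccc12` with 776 nM
- compound 3 `CCCOCc1cc(CN2CCCCC2)c(O)c2ncccc12` with 339 nM

Compound 3 stands at 339 nM as the lowest number of the set, under compound 2 and under both entries of compound 1. The next compound, compound 4 `CC(C)OCc1cc(CN2CCCCC2)c(O)c2ncccc12`, has the same atoms as compound 3, joined differently (isopropyl in place of propyl on an oxygen on a saturated carbon), with isopropyl in place of propyl on an oxygen on a saturated carbon. Among the compounds with values here, the one measured step that bears on this is a 2.3-fold lower number from compound 2 to compound 3 (0.36 log units; beyond the scatter), where methyl replaced hydrogen on a saturated chain carbon. That step added to the chain, whereas this change adds no atoms, so only a small rise in the number is expected in this assay, with part of the gain over compound 2 at 776 nM given back. The expected change is a 1.4-fold higher number from compound 3 to compound 4 (0.15 log units; within the scatter) and may not clear the usual scatter. For compound 4 the estimated value is 480 nM, with an expected range from 240 nM to 850 nM in repeat measurements.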

Compound 4, half-maximal inhibitory concentration: 479 nM
Estimate against measurement, compound 4: 1.0-fold (0.00 log units) above; the measured number falls inside the stated range.
By their numbers in this assay, from the lowest: compounds 3, 4 and 2 (each within the scatter of the next, the first and the last beyond it).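

In this assay, exchanging propyl for isopropyl on an oxygen on a saturated carbon gives a 1.4-fold higher number from compound 3 to compound 4 (0.15 log units; within the scatter), so joining the same atoms differently produces no difference that can be told from the scatter. The comparison with the ethyl ether gives a 1.6-fold lower number from compound 2 to compound 4 (0.21 log units; within the scatter), also within the scatter, whereas the propyl ether's step from that compound, a 2.3-fold lower number from compound 2 to compound 3 (0.36 log units; beyond the scatter), lies beyond it; only the unbranched chain therefore stands clearly apart from compound 2. Repeat entries show how closely readings agreed in this assay: the several entries of compound 1 in this assay, 850 nM; 832 nM (2 entries)

From the compounds shown here alone, whether a longer chain such as butyl would carry the trend further on this oxygen remains open. So does the outcome with a ring such as cyclopropyl, or with an amine in the side chain.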